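The compounds below may be only part of what the source reports. "The series", "measured", "known", "first", "only" and "open" are said of these compounds alone.

Three compounds of the series share one core, joined through a chain to an amide-type nitrogen, and have been run in an ADME assay on MDBK cells (Bos taurus) for cytotoxicity, read by MTT assay; on this read-out higher numbers stand for lower toxicity in this test and lower numbers for higher toxicity in this test. Compound 1 `CC(=O)N(CCCCCCN1C[C@H](O)[C@@H](O)[C@H](O)[C@H]1CO)C1CCCCC1` carries cyclohexyl on that nitrogen, and in this assay compound 1 gives > 500000 nM, which is a limit of the assay rather than a number. Compound 2 `CC(=O)N(CCCCCCN1C[C@H](O)[C@@H](O)[C@H](O)[C@H]1CO)c1ccc(F)cc1F` carries 2,4-difluorophenyl in its place, and in this assay compound 2 gives > 500000 nM, again a limit. The step that the two limits leave unreadable from compound 1 to compound 2 cannot be read; both of its ends are limits. Compound 3 `CC(C)(C)C(=O)N(CCCCCCN1C[C@H](O)[C@@H](O)[C@H](O)[C@H]1CO)c1cc(F)ccc1F` bears a (tert-butyl)carbonyl on the nitrogen, and in this assay compound 3 gives > 500000 nM, also a limit. Compound 3 thus stands where every measured compound stands, at the limit of > 500000 nM in this assay, at which 3 of the 3 values shown sit. Compound 4 `CC(=O)N(CCCCCCN1C[C@H](O)[C@@H](O)[C@H](O)[C@H]1CO)c1cc(F)ccc1F` differs from compound 3 by methyl in place of tert-butyl on a carbonyl carbon. For the measured compounds named here, no measured step bears directly on this change, and the only step at hand is unreadable; compound 1 and compound 2 already carry the acetyl that enters here, and both sit at the limit. The step expected is a step that the limit leaves unreadable from compound 3 to compound 4, none beyond the scatter. Compound 4 is estimated at 800000 nM, with a range of 300000 nM to 3000000 nM, and the reading is expected to come back as a limit once more.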

Compound 4, half-maximal cytotoxic concentration: > 500000 nM
Compound 4 gave a limit, no number; the forecaster's own chance of this, stated with the estimate: 90%; the middle value does not contradict the limit.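

In this assay no new step can be read among compound 1, compound 2, compound 3 and compound 4; each step joins two limits, not numbers, and all four compounds sit at one place: the limit of > 500000 nM in this assay, at which 4 of the 4 values shown sit.

The compounds shown leave open whether the changes on the amide-type nitrogen or the carbonyl carbon have any effect on the read-out in this assay.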